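A few compounds are considered here, and "the series" means these few. Any claim that something is new, unique, unknown or untested is made for them only; others in the source may bear on it.

- compound 1 `COC(=O)CC/C=C\CC[C@H]1C(=O)C[C@@H](O)[C@@H]1/C=C/CC(C)(O)CCC1CCCC1` gives 1.31 mg/kg
- compound 2 `COC(=O)CC/C=C\CC[C@H]1C(=O)C[C@@H](O)[C@@H]1/C=C/CC(C)(O)CCC1=CCCC1` gives 1.18 mg/kg

Within the data shown here, in a functional assay on the whole organism with Rattus norvegicus as the target (on this read-out lower numbers stand for an effect already at smaller amounts and higher numbers for an effect only at larger amounts of compound), compound 2 gives 1.18 mg/kg and stands level with the only other measured compound. Compound 3 `COC(=O)CC/C=C\CC[C@H]1C(=O)C[C@@H](O)[C@@H]1/C=C/C[C@@](C)(O)/C=C/C1CC1` carries 3-cyclopropyl-1-hydroxy-1-methylprop-2-en-1-yl in place of 3-(cyclopent-1-en-1-yl)-1-hydroxy-1-methylpropyl on a saturated chain carbon bound to a double-bonded chain carbon. Among the measured compounds shown here, the sole measured guide is a 1.1-fold lower number from compound 1 to compound 2 (0.05 log units; within the scatter), a swap of cyclopentyl for cyclopent-1-en-1-yl that only partly resembles this larger exchange. No step beyond the scatter is therefore expected, and the estimated step is a 1.2-fold lower number from compound 2 to compound 3 (0.07 log units; within the scatter) with real uncertainty. Compound 3 is estimated at 1 mg/kg with 0.3 mg/kg to 3.5 mg/kg as the expected range.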

Compound 3, dose for half-maximal effect: 0.402 mg/kg
Compound 3: the middle estimate sits 2.5-fold (0.40 log units) above what was measured; low and high end bracket the measured number.
By their numbers in this assay, from the lowest: compound 3; then compounds 2 and 1 (each within the scatter of the next).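

In this assay, among these compounds, this exchange gives the first steps beyond the scatter: 3-cyclopropyl-1-hydroxy-1-methylprop-2-en-1-yl in place of 3-(cyclopent-1-en-1-yl)-1-hydroxy-1-methylpropyl gives a 2.9-fold lower number from compound 2 to compound 3 (0.47 log units; beyond the scatter), and in place of 3-cyclopentyl-1-hydroxy-1-methylpropyl it gives a 3.3-fold lower number from compound 1 to compound 3 (0.51 log units; beyond the scatter). The read-out therefore does respond to a change at this position, which the swap of cyclopentyl for cyclopent-1-en-1-yl alone did not show. No measurement shown here explains the lower numbers. As far as these compounds go, the ring and the chain carrying it change together, so their separate contributions stay unknown. From the compounds shown here alone, how a phenyl group or an amine at the chain end would compare also remains open.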